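A Fused Ring Replaces the Methylphenyl Group

A few compounds are considered here, and "the series" means these few. Any claim that something is new, unique, unknown or untested is made for them only; others in the source may bear on it.

compound 1 `COc1cc(-c2ccnc3cc(-c4ccc(C)cc4)nn23)cc(OC)c1OC`: 48 nM
compound 2 `COc1cc(-c2ccnc3cc(-c4cn(C)c5ccccc45)nn23)cc(OC)c1OC`: 762 nM

In a functional assay on HCT-116 cells (Homo sapiens) for inhibition, read by CCK-8 assay, with a stated time of 48 h (on this read-out higher numbers stand for weaker inhibition and lower numbers for stronger inhibition), compound 1 gives 48 nM, the lowest of the two numbers; compound 2 gives 762 nM. Compound 3 `COc1cc(-c2ccnc3cc(-c4ccc5cnn(C)c5c4)nn23)cc(OC)c1OC` differs from compound 1 in one place: 1-methyl-1H-indazol-6-yl in place of 4-methylphenyl on an aromatic carbon. Going by the values given here, the only measured step that bears on this change is a 16-fold higher number from compound 1 to compound 2 (1.20 log units; beyond the scatter), where the 4-methylphenyl group was likewise exchanged for a fused aromatic group and inhibition became markedly weaker. A loss of similar kind, though perhaps somewhat smaller, is expected here, a 6.3-fold higher number from compound 1 to compound 3 (0.80 log units; beyond the scatter), because a 16-fold higher number from compound 1 to compound 2 (1.20 log units; beyond the scatter) was large. Compound 3 is therefore estimated at 300 nM, with a range from 80 nM to 1200 nM.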

Compound 3, half-maximal inhibitory concentration: 2440 nM
Estimate against measurement, compound 3: 8.1-fold (0.91 log units) below; the whole stated range lies below it.
By their numbers in this assay, from the lowest: compound 1; then compound 2; then compound 3.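

In this assay, 1-methyl-1H-indazol-6-yl in place of 4-methylphenyl gives a 51-fold higher number from compound 1 to compound 3 (1.71 log units; beyond the scatter), so a second fused group on this aromatic carbon also weakens inhibition, and by more than the first. The two fused groups are not interchangeable either, as the exchange between them gives a 3.2-fold higher number from compound 2 to compound 3 (0.51 log units; beyond the scatter). No measurement available here explains either result. Still open, going by these compounds, is whether the fused ring itself or its ring nitrogen atoms matter more. A naphthyl group, fused but of carbon only, or a phenyl ring carrying an amine, would bear on that question.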